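The compounds below may be only part of what the source reports. "The series", "measured", "known", "first", "only" and "open" are said of these compounds alone.

Series notes. The three measured compounds share one core and one amide link to the aromatic ring that carries the acetyl or oxime group. Compound 1 `C=CCn1c(SCC(=O)Nc2ccc(C(C)=O)cc2)nnc1-c1ccccc1` carries an allyl group on the ring nitrogen and an acetyl group on the aromatic carbon; in a functional assay on the whole organism (strain albino) for inhibition, with Rattus norvegicus as the target, read by paw edema, with stated times of 30 min and 4 h, at a dose of 0.28 mmol/kg by the oral route (a lower number here means less inhibition, a higher number more inhibition at the dose given (going by the name of the read-out)), compound 1 gives 70%. Compound 3 `C=CCn1c(SCC(=O)Nc2ccc(/C(C)=N/O)cc2)nnc1-c1ccccc1` keeps the allyl group and carries the oxime in place of the acetyl; in this assay compound 3 gives 73%. Among the measured compounds shown here, that single change is the only measured step, a number 3 percentage points higher from compound 1 to compound 3 (within the scatter). Compound 2 `COc1cc(-c2nnc(SCC(=O)Nc3ccc(/C(C)=N/O)cc3)n2-c2ccccc2)cc(OC)c1OC` carries a phenyl on the ring nitrogen and a trimethoxyphenyl at the other position; in this assay compound 2 gives 75%. Compound 3 stands second of the three numbers, with compound 2 close above and compound 1 close below, both within the scatter.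

Compound 4 `C/C(=N\O)c1ccc(NC(=O)CSc2nnc(-c3ccccc3)n2-c2ccccc2)cc1`, not yet measured, differs from compound 3 in one place: phenyl in place of allyl on an aromatic nitrogen. For the measured compounds named here, no measured step covers this change alone; compound 2 and compound 3 differ in two places, and their values lie within the scatter of each other. Going by the values given here, the one measured step, on a different position, is itself within the scatter. In this assay the expected step from compound 3 is therefore no change at the digits printed from compound 3 to compound 4 (within the scatter), none beyond the scatter. Compound 4 is estimated at 73%, range 60% to 85%.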

Compound 4, a percentage reported as inhibition, in the whole organism at one dose (the size of the read-out at that dose, not a potency): 67%
Compound 4: middle estimate off by 6 percentage points, on the high side; the measured number falls inside the stated range.
By their numbers in this assay, from the lowest: compounds 4, 1, 3 and 2 (each within the scatter of the next).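

Among the compounds shown here, with compound 4, the group on the aromatic nitrogen can be read alone for the first time: in this assay, phenyl in place of allyl gives a number 6 percentage points lower from compound 3 to compound 4 (within the scatter), so this swap of a chain for an aromatic ring shows no effect that can be told from the scatter. Compound 4 also isolates the aromatic carbon position, where phenyl in place of 3,4,5-trimethoxyphenyl gives a number 8 percentage points lower from compound 2 to compound 4 (within the scatter), so the three methoxy groups likewise show no effect that can be told from the scatter at this single dose. Nothing available bears on the reason for either step, and neither step needs one to be read.

The compounds shown leave open whether a methyl or benzyl group, or a chain ending in an amine, on the aromatic nitrogen would give a step beyond the scatter, and whether a carboxylic acid on the phenyl at the aromatic carbon would do so. They also leave open whether the acetyl-to-oxime step, a number 3 percentage points higher from compound 1 to compound 3 (within the scatter), keeps its size when phenyl rather than allyl sits on the aromatic nitrogen.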